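A few compounds are considered here, and "the series" means these few. Any claim that something is new, unique, unknown or untested is made for them only; others in the source may bear on it.

Compound 1 `CC(C)(C)C#Cc1cc(N(C(=O)[C@H]2CC[C@H](C)CC2)[C@H]2CC[C@H](Oc3ccc4nccn4n3)CC2)c(C(=O)O)s1`: > 20000 nM
Compound 2 `CC1CC=C(C(=O)N(c2cc(C#CC(C)(C)C)sc2C(=O)O)C(C)C)CC1`: > 20000 nM
Compound 3 `CC1=CC[C@H](C(=O)N(c2cc(C#CC(C)(C)C)sc2C(=O)O)[C@H]2CC[C@](O)(CO[C@H]3CCOC3)CC2)CC1`: > 20000 nM

All three entries come from an ADME assay on MT4 cells (Homo sapiens) for cytotoxicity, with a stated time of 5 days; on this read-out lower numbers stand for higher toxicity in this test and higher numbers for lower toxicity in this test. Compound 1 gives > 20000 nM, which is a limit of the assay and not a number. The entries for compound 2 and compound 3 are limits as well. Within the data shown here, the series therefore offers no graded values so far, only this: the limit of > 20000 nM in this assay, at which 3 of the 3 values shown sit.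

The next compound to be read is compound 4 `CC(C)(C)C#Cc1cc(N(C(=O)[C@H]2CC[C@H](C)CC2)[C@H]2CC[C@H](Oc3ccc(=O)[nH]n3)CC2)c(C(=O)O)s1`, which keeps the core of compound 1 and changes only the group on an oxygen on a saturated carbon: a group of 7 heavy atoms (4 carbon, 2 nitrogen, 1 oxygen; one six-membered aromatic ring with 2 hetero atoms) in place of a group of 9 heavy atoms (6 carbon, 3 nitrogen; one five-membered aromatic ring with 2 hetero atoms, one six-membered aromatic ring with 2 hetero atoms), on an oxygen on a saturated carbon. In words, a group with one six-membered aromatic ring with 2 hetero atoms takes the place of a group with one five-membered and one six-membered aromatic ring.

Among the measured compounds shown here, no step between measured compounds is available to size this change. For the measured compounds named here, no shift beyond the usual scatter is expected in this assay, in either direction, because compound 1 stands at > 20000 nM and nothing measured so far falls short of that limit. The estimated change is a step that the limit leaves unreadable from compound 1 to compound 4. For compound 4 the expected value is 25000 nM, with an estimated range from 12000 nM to 50000 nM, and a report as a limit is the likely outcome.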

Compound 4, half-maximal cytotoxic concentration: > 20000 nM
Compound 4 gave a limit, no number (the forecaster's own chance of this, stated with the estimate: 85%); the middle value lies beyond the limit too.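

In this assay compound 4 gives > 20000 nM which is a limit of the assay and not a number. Among these compounds, compound 1 also stands at a limit, and no step from compound 1 to compound 4 can be read. The compounds shown leave open which change, if any, would give a graded value, as every entry stands at one limit: the limit of > 20000 nM in this assay, at which 4 of the 4 values shown sit.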